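Trimethoxy to dimethoxy swap across two urea cores

The source may report more compounds than this note shows. Statements on the series, on what has been measured and on what is new or still open speak of the compounds shown alone.

Compound 1 `COc1cc(CN(C(=O)Nc2cc(C(F)(F)F)cc(C(F)(F)F)c2)n2cnnc2)cc(OC)c1OC` and compound 3 `COc1ccc(CN(C(=O)Nc2cc(C(F)(F)F)cc(C(F)(F)F)c2)n2cnnc2)cc1OC` share one core; compound 2 `CCc1ccc(NC(=O)N(Cc2cc(OC)c(OC)c(OC)c2)n2cnnc2)cc1` and compound 4 `CCc1ccc(NC(=O)N(Cc2ccc(OC)c(OC)c2)n2cnnc2)cc1` share another, and the difference between the two cores is not broken down here. In a functional assay on MCF7 cells (Homo sapiens) for cytotoxicity, read by MTT assay, with a stated time of 48 h (a lower number here means a stronger inhibitor, a higher number a weaker inhibitor), compound 1 gives 23800 nM, compound 3 gives 15500 nM and compound 2 gives 24800 nM. Compound 3 arises from compound 1 by the change (hydrogen in place of methoxy on an aromatic carbon), and that step reads a 1.5-fold lower number from compound 1 to compound 3 (0.19 log units; within the scatter). Compound 4 arises from compound 2 by the change (hydrogen in place of methoxy on an aromatic carbon), at a place described in the same words. For compound 4 the expected step is a 1.5-fold lower number from compound 2 to compound 4 (0.16 log units; within the scatter), kept small in line with a 1.5-fold lower number from compound 1 to compound 3 (0.19 log units; within the scatter) falling within the scatter. Compound 4 is therefore estimated at 17000 nM, with a likely range from 8000 nM to 40000 nM.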

Compound 4, half-maximal inhibitory concentration: > 50000 nM
Compound 4: a limit, no number; the forecaster's own chance of this, stated with the estimate: 5%; middle value at least 2.9-fold (0.46 log units) away from the limit.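

In this assay the new step reads an at least 2.0-fold higher number from compound 2 to compound 4 (0.30 log units; that floor lies within the scatter), so hydrogen in place of methoxy on an aromatic carbon does not give the same outcome on the two cores: the same change on two cores in this assay, a 1.5-fold lower number (0.19 log units; within the scatter) from compound 1 to compound 3 and an at least 2.0-fold higher number (0.30 log units; that floor lies within the scatter) from compound 2 to compound 4, at least 3.0-fold (0.49 log units) apart, beyond the scatter of two such steps

Compound 4 stands at a limit of the assay and not at a number: the limit of > 50000 nM in this assay, at which 1 of the 4 values shown sits.

These two pairs show that the result of this change differs between the two cores, but they do not give the full size of the step on the second core, and two pairs set no rule for the series.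

The compounds shown leave open which difference between the cores goes with the split result. They also leave open how the same change would read with an amine, a carboxylic acid or a longer chain in place of the ethyl group.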